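Sulfonamide series: aryl swap on the sulfonyl sulfur

A few compounds are considered here, and "the series" means these few. Any claim that something is new, unique, unknown or untested is made for them only; others in the source may bear on it.

Working notes on two measured compounds and one unmeasured analogue, all sharing one core. In an assay on isolated protein for inhibition of malate dehydrogenase, mitochondrial (Sus scrofa), with stated times of 45 min and 30 min (a lower number here means a stronger inhibitor, a higher number a weaker inhibitor), compound 1 `O=S(=O)(Nc1ccc(-c2nc3ccccc3o2)cc1)c1ccc(Cl)c(C(F)(F)F)c1` gives only a limit, > 63000 nM, and no number. Compound 2 `Cc1ccc(S(=O)(=O)Nc2ccc(-c3nc4ccccc4o3)cc2)cc1` likewise gives only a limit in this assay, > 63000 nM. Going by the values given here, compound 2 therefore stands at the limit of this assay, with no measured number to place it, and the same holds for the one other value known so far (the limit of > 63000 nM in this assay, at which 2 of the 2 values shown sit).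

Compound 3 `O=S(=O)(Nc1ccc(-c2nc3ccccc3o2)cc1)c1ccccc1Cl` differs from compound 2 in one place: 2-chlorophenyl in place of 4-methylphenyl on a sulfonyl sulfur. Among the compounds with values here, no step between measured compounds is known, so nothing shows how a change on the sulfonyl sulfur moves this assay. Both measured compounds sit at the limit, and the expectation is that the step from compound 2 to compound 3 stays at the limit as well, with no shift beyond the scatter resolvable: a step that the limit leaves unreadable from compound 2 to compound 3 is the expected step. Compound 3 is estimated at 100000 nM in this assay, with a range from 30000 nM to 400000 nM, and most likely the assay again reports only a limit.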

Compound 3, half-maximal inhibitory concentration: > 63000 nM
Compound 3 ended at the assay's limit; the forecaster's own chance of this, stated with the estimate: 85%; the middle value does not contradict the limit.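

No step can be read from compound 2 to compound 3: in this assay both give only a limit, and the size of the change to 2-chlorophenyl in place of 4-methylphenyl on a sulfonyl sulfur stays unreadable. All values shown stand at the same point: the limit of > 63000 nM in this assay, at which 3 of the 3 values shown sit.

The compounds shown leave open whether any group on the sulfonyl sulfur of the shared core gives a measured number in this assay.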